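The compounds below may be only part of what the source reports. "The series", "measured", "known", "first", "only" and "open" are said of these compounds alone.

Of the compounds shown here, three with a shared core have so far been measured in a functional assay for inhibition, with Rattus norvegicus as the target; a higher number here means a weaker inhibitor, a lower number a stronger inhibitor. Compound 1, `CNc1nc(Cl)nc2c1ncn2CC(COC(=S)SCc1ccccc1)COC(=S)SCc1ccccc1`, gives 87000 nM in this assay. Compound 2, `CNc1nc(Cl)nc2c1ncn2CC(COC(=O)CCC(=O)O)COC(=O)CCC(=O)O`, gives 18000 nM in this assay. Compound 3, `CNc1nc(Cl)nc2c1ncn2C1C[C@@H](OC(=O)NC(C)C)[C@@H](COP(=O)(O)O)O1`, gives 6400 nM in this assay, the lowest of the three numbers; its gaps to compound 2 and to compound 1 both lie beyond the usual scatter of repeated measurements, so among these three compound 3 is the strongest inhibitor.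

Compound 4, `CCNC(=O)O[C@@H]1CC(n2cnc3c(NC)nc(Cl)nc32)O[C@@H]1COP(=O)(O)O`, has not yet been measured. It differs from compound 3 in one place: hydrogen in place of methyl on a saturated chain carbon bound to an amide-type nitrogen and a saturated chain carbon. Cut one bond further out, the same difference reads isopropylcarbamoyl to ethylcarbamoyl. The change removes a single carbon from a saturated chain and touches no ring, no hydrogen-bond donor or acceptor and no charge.

For the measured compounds named here, no step between measured compounds with a change of this kind is available, so the expectation rests on the size of the change alone. Because compound 3 already gives 6400 nM in this assay, compound 4 is expected to stay close to it, with a step of a 1.1-fold higher number from compound 3 to compound 4 (0.04 log units; within the scatter) that should fall within the scatter and in no clear direction. Compound 4 is therefore estimated at 7000 nM in this assay, in a range from 3000 nM to 16000 nM.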

Compound 4, inhibition constant: 11000 nM
Estimate against measurement, compound 4: 1.6-fold (0.20 log units) below, and the stated range covers the measured number.
By their numbers in this assay, from the lowest: compounds 3, 4 and 2 (each within the scatter of the next, the first and the last beyond it); then compound 1.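

In this assay, for the compounds shown here, a step of a 1.7-fold higher number from compound 3 to compound 4 (0.24 log units; within the scatter) gives the first reading of any change at this place, and it lies within the scatter. Going by these compounds alone, replacing methyl with hydrogen on the saturated chain carbon bound to an amide-type nitrogen and a saturated chain carbon, which turns isopropylcarbamoyl into ethylcarbamoyl, therefore separates the two compounds by nothing that can be told from repeated measurement, something the earlier compounds could not show, as no two of them differed in one place. No measurement bears on what lies behind this result, and it rests on a single pair.

The compounds shown leave open whether a shorter methylcarbamoyl, a longer chain such as butylcarbamoyl, or a ring such as cyclohexylcarbamoyl would also stay within the scatter of compound 3, which gives 6400 nM. They also leave open whether a carboxylic acid or an amine at the end of that chain would give a number clearly apart from those of compound 3 and compound 4.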